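The source may hold more compounds than are shown below. What is called first, only, known or untested is meant among the compounds shown, and "the series" means these compounds.

Measured compounds in a functional assay on Mahlavu cells (Homo sapiens) for antiproliferative activity, read by sulforhodamine B assay, with a stated time of 72 h; a higher number here means a weaker inhibitor, a lower number a stronger inhibitor:
compound 1 `FC(F)(F)c1ccc(CN2CCN(Cc3cc(-c4ccc(OCc5ccccc5Cl)cc4)on3)CC2)cc1`: 3200 nM
compound 2 `N#Cc1ccccc1COc1ccc(-c2cc(CN3CCN(Cc4ccc(C(F)(F)F)cc4)CC3)no2)cc1`: 3500 nM

Compound 1 holds the lowest of the two numbers, and compound 2 sits within the scatter of it: a 1.1-fold higher number from compound 1 to compound 2 (0.04 log units; within the scatter), for cyano in place of chloro on an aromatic carbon. Compound 3 `COc1cc(COc2ccc(-c3cc(CN4CCN(Cc5ccc(C(F)(F)F)cc5)CC4)no3)cc2)cc(OC)c1OC` differs from compound 1 by 3,4,5-trimethoxyphenyl in place of 2-chlorophenyl on a saturated chain carbon bound to an oxygen on an aromatic ring. Among the measured compounds shown here, the only measured step touches the same region but is far smaller in scope, so no step beyond the scatter is expected in this assay. Compound 3 is expected to give 3500 nM, within 1200 nM to 11000 nM. The expected step is a 1.1-fold higher number from compound 1 to compound 3 (0.04 log units; within the scatter).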

Compound 3, half-maximal inhibitory concentration: 5800 nM
For compound 3 the middle estimate is 1.7-fold (0.22 log units) below the measured one, within the range that was stated.
By their numbers in this assay, from the lowest: compounds 1, 2 and 3 (each within the scatter of the next).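

In this assay, the saturated chain carbon bound to an oxygen on an aromatic ring also carries 3,4,5-trimethoxyphenyl, with 12 heavy atoms and 3 hydrogen-bond acceptors. The steps of a 1.8-fold higher number from compound 1 to compound 3 (0.26 log units; within the scatter) and a 1.7-fold higher number from compound 2 to compound 3 (0.22 log units; within the scatter) both stay within the scatter, so this much larger exchange separates the compounds no better than the swap of cyano for chloro did. No measurement at hand accounts for this. Still open, going by these compounds, is whether an amine or a carboxylic acid on this ring would give a step beyond the scatter.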